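The compounds below may be only part of what the source reports. "The series", "measured", "known", "first", "only" and "open" are said of these compounds alone.

Compounds measured in a functional assay on MCF7 cells (Homo sapiens) for antiproliferative activity, read by MTT assay, with a stated time of 48 h; on this read-out higher numbers stand for weaker inhibition and lower numbers for stronger inhibition:
compound 1 `CC(=O)Nc1ccc(-n2nncc2CN2C(=O)C3(C(C#N)=C(N)Oc4c(N)cc5nc6ccccc6nc5c43)c3ccccc32)cc1` > 50000 nM
compound 2 `CCc1cccc(CC)c1-n1nncc1CN1C(=O)C2(C(C#N)=C(N)Oc3c(N)cc4nc5ccccc5nc4c32)c2ccccc21` > 50000 nM
compound 3 `N#CC1=C(N)Oc2c(N)cc3nc4ccccc4nc3c2C12C(=O)N(Cc1cnnn1-c1c(F)cccc1F)c1ccccc12` > 50000 nM

Compound 3 `N#CC1=C(N)Oc2c(N)cc3nc4ccccc4nc3c2C12C(=O)N(Cc1cnnn1-c1c(F)cccc1F)c1ccccc12` stands at a limit of this assay: its reading of > 50000 nM is not a number. The same holds for compound 1, whose value > 50000 nM is a limit. It holds again for compound 2, whose value > 50000 nM is a limit. Within the data shown here, all three values sit at the one limit (the limit of > 50000 nM in this assay, at which 3 of the 3 values shown sit), so no step between them can be read: a step that the two limits leave unreadable from compound 1 to compound 2, a step that the two limits leave unreadable from compound 1 to compound 3 and a step that the two limits leave unreadable from compound 2 to compound 3 are all left open by the two limits.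

Compound 4 `N#CC1=C(N)Oc2c(N)cc3nc4ccccc4nc3c2C12C(=O)N(Cc1cnnn1-c1ccc([N+](=O)[O-])cc1[N+](=O)[O-])c1ccccc12` differs from compound 3 by 2,4-dinitrophenyl in place of 2,6-difluorophenyl on an aromatic nitrogen. Among the measured compounds shown here, each of the measured steps bears on this change only in that it swaps the group on that aromatic nitrogen, and each of them is unreadable, so they give no size and no direction for the step in this assay. Compound 4 is therefore expected to come back at the same limit, and its estimate is 60000 nM with a range from 20000 nM to 200000 nM, which means an expected step that the limit leaves unreadable from compound 3 to compound 4.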

Compound 4, half-maximal inhibitory concentration: 20900 nM
For compound 4 the middle estimate is 2.9-fold (0.46 log units) above the measured one; measured number inside the range.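

Among these compounds, on the aromatic nitrogen, a change of group can now be read in this assay, where none of the earlier steps could: 2,4-dinitrophenyl in place of 2,6-difluorophenyl gives an at least 2.3-fold lower number from compound 3 to compound 4 (0.37 log units; beyond the scatter). Set against the other two groups on that nitrogen, 2,4-dinitrophenyl gives an at least 2.3-fold lower number from compound 2 to compound 4 (0.37 log units; beyond the scatter) and an at least 2.3-fold lower number from compound 1 to compound 4 (0.37 log units; beyond the scatter). As far as these compounds go, these steps give only a smallest size, and the full size stays unknown, as the other three compounds share one limit: the limit of > 50000 nM in this assay, at which 3 of the 4 values shown sit.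

The compounds shown leave open whether both nitro groups are needed or a phenyl ring carrying a single nitro group would give the same reading. They also leave open what an amine or a carboxylic acid in place of the nitro groups would do on this read-out.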